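This account rests on a few compounds, and the source may have more. Where it says the series, first, only, none or still open, it means among the compounds named here.

Working notes on the series. In a functional assay on HEK293 cells for agonist activity at D(4) dopamine receptor (Homo sapiens), read by FLIPR (a lower number here means that less compound is needed, a higher number that more compound is needed for the effect), compound 2 `O=C(NCN1CCC(c2cccc[n+]2[O-])CC1)c1ccc(F)c(Cl)c1` gives 63 nM, the lowest of the three numbers in hand; compound 1 `O=C(CN1CCC(c2ccccn2)CC1)Nc1c(Cl)cc(Cl)cc1Cl` gives 145 nM and compound 3 `O=C(NCN1CCC(c2cccc[n+]2[O-])CC1)c1ccc(OC(F)(F)F)c(Cl)c1` gives 170 nM. Among the compounds with values here, the one single-point step measured so far, a 2.7-fold higher number from compound 2 to compound 3 (0.43 log units; beyond the scatter), came from trifluoromethoxy in place of fluoro on an aromatic carbon. Compound 4 `Cc1ccc(C(=O)NCN2CCC(c3cccc[n+]3[O-])CC2)cc1C` differs from compound 2 by 3,4-dimethylphenyl in place of 3-chloro-4-fluorophenyl on a carbonyl carbon. Within the data shown here, no measured step exchanges both halogens for methyl groups, so the step from compound 2 to compound 3 is the only guide, and it was modest and toward a higher number. A modest step in the same direction is therefore expected, a 1.7-fold higher number from compound 2 to compound 4 (0.24 log units; within the scatter). For compound 4 the estimate in this assay is 110 nM, with a range from 40 nM to 300 nM.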

Compound 4, half-maximal effective concentration: 38 nM
For compound 4 the middle estimate is 2.9-fold (0.46 log units) above the measured one; measured number below the stated range.
By their numbers in this assay, from the lowest: compounds 4 and 2 (each within the scatter of the next); then compounds 1 and 3 (each within the scatter of the next).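

In this assay the exchange of both halogens for methyl groups gives a 1.7-fold lower number from compound 2 to compound 4 (0.22 log units; within the scatter) and leaves compound 2 and compound 4 indistinguishable, so on this carbonyl carbon an aryl group without any halogen serves as well as 3-chloro-4-fluorophenyl. Within the data shown here, the only step beyond the scatter at this position remains a 2.7-fold higher number from compound 2 to compound 3 (0.43 log units; beyond the scatter) with trifluoromethoxy as the entering group. Nothing measured on hand explains why the two aryl groups read alike. On these data alone, whether a single methyl group would read the same stays open, as does the reading of a methoxy group or a nitrile on this ring.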